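A Chlorophenyl Swap Checked for Cell Toxicity

This account rests on a few compounds, and the source may have more. Where it says the series, first, only, none or still open, it means among the compounds named here.

Compound 1 `CC1=C(C(=O)OCc2ccccc2)C(c2cccc(O)c2)NC(=O)N1` in an ADME assay on CEMx174 cells (Homo sapiens) for cytotoxicity (on this read-out lower numbers stand for higher toxicity in this test and higher numbers for lower toxicity in this test), gives a limit of > 10000 nM.
Compound 2 `CCCC1=C(C(=O)OCC2CCCCC2)C(c2cccc(O)c2)NC(=O)N1` gives a limit of > 10000 nM in this assay.
Compound 3 `CCC1=C(C(=O)OCC2CCCCC2)C(c2cccc(N)c2)NC(=O)N1` gives a limit of > 10000 nM in this assay.

Compound 3 thus stands where the other two measured compounds stand: the test reports only a limit for it, not a number, and the same holds for compound 1 and compound 2. All three values sit at the limit of > 10000 nM in this assay, at which 3 of the 3 values shown sit, so nothing in the measured set separates one compound from another in this assay.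

Compound 4 `CCC1=C(C(=O)OCC2CCCCC2)C(c2ccc(Cl)cc2)NC(=O)N1` differs from compound 3 in one place: 4-chlorophenyl in place of 3-aminophenyl on a saturated ring carbon. Among the measured compounds shown here, no step between two measured compounds is known, so the numbers give no direction for this change. Since every measured compound sits at the same limit, the change from compound 3 to compound 4 is expected to give a number no higher from compound 3 to compound 4 (the limit leaves the size open), a step of no size beyond the scatter. Compound 4 is expected to come out at 10000 nM, with a range from 5000 nM to 30000 nM, most likely reported again as a limit.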

Compound 4, half-maximal cytotoxic concentration: > 10000 nM
Compound 4: only a limit was reported (the forecaster's own chance of this, stated with the estimate: 75%); the middle value lies on the limit itself.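

Compound 3 and compound 4 are both reported only as limits in this assay, so no step can be read between them. The compounds shown leave open how toxic each one actually is to these cells, and whether 4-chlorophenyl and 3-aminophenyl differ at all in this test.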